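Replacing a hydroxybutyl chain with an ethoxy group

The source may hold more compounds than are shown below. What is called first, only, known or untested is meant among the compounds shown, and "the series" means these compounds.

Three compounds share one core and differ only in the chain that hangs from a saturated ring carbon. Compound 1 `Cn1c(-c2ccccc2C(F)(F)F)nnc1C12CCC(CCS(C)(=O)=O)(CC1)CC2`, compound 2 `Cn1c(-c2ccccc2C(F)(F)F)nnc1C12CCC(COc3ccc(S(C)(=O)=O)cc3)(CC1)CC2` and compound 3 `CC(O)CCCC12CCC(c3nnc(-c4ccccc4C(F)(F)F)n3C)(CC1)CC2` were all tested in an assay on CHO-K1 cells for inhibition of 11-beta-hydroxysteroid dehydrogenase type 2 (Mus musculus), read by scintillation proximity assay; on this read-out higher numbers stand for weaker inhibition and lower numbers for stronger inhibition. For compound 1 the result is only a limit, > 4000 nM. For compound 2 the result is likewise a limit, > 4000 nM. For compound 3 the result is again a limit, > 4000 nM. Because of this (the limit of > 4000 nM in this assay, at which 3 of the 3 values shown sit), the steps a step that the two limits leave unreadable from compound 1 to compound 2, a step that the two limits leave unreadable from compound 1 to compound 3 and a step that the two limits leave unreadable from compound 2 to compound 3 cannot be sized, and compound 3 cannot be placed above or below its neighbours.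

Compound 4 `CCOCC12CCC(c3nnc(-c4ccccc4C(F)(F)F)n3C)(CC1)CC2` has not yet been measured. It carries ethoxy in place of 3-hydroxybutyl on a saturated chain carbon bound to a saturated ring carbon. Going by the values given here, none of the measured steps can be read, so they give no direction for this change; what they do show is that every chain tried so far left the compounds at the limit. The step that the limit leaves unreadable from compound 3 to compound 4 is therefore expected to be small or unreadable. Compound 4 is estimated at 8000 nM, within a range from 3000 nM to 30000 nM, most likely again reported as a limit.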

Compound 4, half-maximal inhibitory concentration: > 4000 nM
Compound 4 was reported as a limit; the forecaster's own chance of this, stated with the estimate: 80%; the middle value lies beyond the limit too.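

The result for compound 4 is also only a limit, so its steps from compound 1, compound 2 and compound 3 cannot be read, because all four compounds end at the same point: the limit of > 4000 nM in this assay, at which 4 of the 4 values shown sit.

The compounds shown leave open how strongly any of the four inhibits the enzyme, and whether any chain on the shared core would give a measurable number.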